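This account rests on a few compounds, and the source may have more. Where it says the series, first, only, none or still open, it means among the compounds named here.

Values so far in a functional assay on HepG2 cells (Homo sapiens) for inhibition, read by MTT assay, with a stated time of 24 h; a lower number here means a stronger inhibitor, a higher number a weaker inhibitor
compound 1 `CC1(C)[C@H]2CC[C@]1(C)N(Cc1cn(-c3cccc(F)c3)nn1)C(=O)C2` gives 80 nM
compound 2 `CC1(C)[C@H]2CC[C@]1(C)N(Cc1cn(-c3ccc(C#N)cc3)nn1)C(=O)C2` gives 50 nM
compound 3 `CC1(C)[C@H]2CC[C@]1(C)N(Cc1cn(-c3cccc(C#N)c3)nn1)C(=O)C2` gives 40 nM

Compound 3 cannot be separated from the other two, since its steps are a 1.3-fold lower number from compound 2 to compound 3 (0.10 log units; within the scatter) and a 2.0-fold lower number from compound 1 to compound 3 (0.30 log units; within the scatter) and neither stands clear of the scatter.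

The next structure is compound 4 `CC1(C)[C@H]2CC[C@]1(C)N(Cc1cn(-c3ccc(F)cc3)nn1)C(=O)C2` with the change 4-fluorophenyl in place of 3-cyanophenyl on an aromatic nitrogen in which 4-fluorophenyl takes the place of 3-cyanophenyl on an aromatic nitrogen. Among the compounds with values here, three measured steps bear on this. The swap of fluoro for cyano runs against a 2.0-fold lower number from compound 1 to compound 3 (0.30 log units; within the scatter) and the shift between the two cyanophenyl groups is a 1.3-fold lower number from compound 2 to compound 3 (0.10 log units; within the scatter) while the remaining step is a 1.6-fold lower number from compound 1 to compound 2 (0.20 log units; within the scatter) and all three are small. Within the data shown here, no measured compound carries 4-fluorophenyl, so that group itself is untested.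

The reversal of a 2.0-fold lower number from compound 1 to compound 3 (0.30 log units; within the scatter) gives the only hint of direction, towards a somewhat higher number in this assay with nothing expected beyond the scatter. The expected step is a 1.8-fold higher number from compound 3 to compound 4 (0.24 log units; within the scatter) and this remains a weak expectation. In this assay the estimated value for compound 4 is 70 nM with an expected range of 35 nM to 150 nM still to be tested.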

Compound 4, half-maximal inhibitory concentration: 90 nM
Estimate against measurement, compound 4: 1.3-fold (0.11 log units) below; the measured number falls inside the stated range.
By their numbers in this assay, from the lowest: compounds 3, 2, 1 and 4 (each within the scatter of the next, the first and the last beyond it).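

In this assay, within the data shown here, a 2.3-fold higher number from compound 3 to compound 4 (0.35 log units; beyond the scatter) is the first step to stand clear of the scatter, so the aryl group on the aromatic nitrogen can register, though only modestly. Neither component of that change does so alone: moving the fluoro group gives a 1.1-fold higher number from compound 1 to compound 4 (0.05 log units; within the scatter), and fluoro in place of cyano on the 4-substituted phenyl gives a 1.8-fold higher number from compound 2 to compound 4 (0.26 log units; within the scatter), both within the scatter, so the separation appears only where the group and its place change together. Cyano in place of fluoro can now be read on two pairs, and although neither step clears the scatter, the two agree in direction and size: the same change on two cores in this assay, a 2.0-fold lower number (0.30 log units; within the scatter) from compound 1 to compound 3 and a 1.8-fold lower number (0.26 log units; within the scatter) from compound 4 to compound 2, 1.1-fold (0.05 log units) apart, within the scatter of two such steps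

The compounds shown carry only fluoro and cyano on the phenyl group, which leaves open how an amine, a carboxylic acid or a longer chain there would read in this assay. On these data alone, the shared core is also the same throughout, so what it contributes to these numbers remains open.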